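Exchanging an aromatic group with both neighbours at a limit

This account rests on a few compounds, and the source may have more. Where it says the series, first, only, none or still open, it means among the compounds named here.

compound 1 `CCCS(=O)(=O)N1CCC(CNC(=O)c2c(F)cccc2F)(C(=O)N2CCOCC2)CC1` with < 1.4
compound 2 `CCCS(=O)(=O)N1CCC(CNC(=O)c2c(F)ccc(Cl)c2F)(C(=O)N2CCOCC2)CC1` with < 1.4

In a physicochemical assay for lipophilicity (on this read-out higher numbers stand for higher lipophilicity and lower numbers for lower lipophilicity), compound 2 gives < 1.4 as a limit, not as a number. Compound 1 gives < 1.4 and that is a limit too. The next molecule, compound 3 `CCCS(=O)(=O)N1CCC(CNC(=O)c2ccccc2Cl)(C(=O)N2CCOCC2)CC1`, differs from compound 2 as follows: 2-chlorophenyl in place of 3-chloro-2,6-difluorophenyl on a carbonyl carbon.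

Among the measured compounds shown here, only one measured step bears on this exchange, and it offers no size to work with: a step that the two limits leave unreadable from compound 1 to compound 2. The other guide is the limit of < 1.4 in this assay, at which 2 of the 2 values shown sit, which gives no direction either. Resting on these two, no clear step in either direction is expected in this assay. The estimated change is a step that the limit leaves unreadable from compound 2 to compound 3 and remains a rough expectation. For compound 3 the expected value is 1.1, with an estimated range from 0.7 to 1.5, and a report of only a limit is quite likely.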

Compound 3, partition coefficient: < 1.4
Compound 3: a limit, no number; the forecaster's own chance of this, stated with the estimate: 80%; the middle value lies beyond the limit too.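

No step can be read among compound 1, compound 2 and compound 3 in this assay, since each gives only a limit and no number. The size and even the direction of any difference among these three compounds stay open, with only this to go on: the limit of < 1.4 in this assay, at which 3 of the 3 values shown sit.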